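The compounds below may be only part of what the source reports. "The series", "measured", "known", "first", "only" and "open" are said of these compounds alone.

Measured compounds: compound 1 `NC(N)=NC(=O)c1nc(Cl)c(NCC2CCCCC2)nc1N` with 96%; compound 2 `CCCN(C)c1nc(N)c(C(=O)N=C(N)N)nc1Cl` with 91%; compound 3 `CN(c1nc(N)c(C(=O)N=C(N)N)nc1Cl)C1CCCCC1` with 57%.

All three share one core and differ only in the amino group on it. In an assay for inhibition of acid-sensing ion channel 3 (Homo sapiens), read by patch clamp, tested at 20 uM (on this read-out lower numbers stand for less inhibition and higher numbers for more inhibition at the one concentration tested (going by the name of the read-out)), compound 2 gives 91%, the second highest of the three numbers. Its nearest neighbour is compound 1 with 96%, a gap within the scatter, so no order can be read between these two. Its furthest neighbour is compound 3 with 57%, a gap that lies beyond the scatter.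

The unmeasured compound 4 `NC(N)=NC(=O)c1nc(Cl)c(Nc2ccccn2)nc1N` is reached from compound 2 by one change: (pyridin-2-yl)amino in place of methyl(propyl)amino on an aromatic carbon.

One measured step speaks to this change. From compound 2 to compound 3, cyclohexyl in place of propyl on the same nitrogen gave a number 34 percentage points lower from compound 2 to compound 3 (beyond the scatter), a large fall when a ring was brought in. Among the measured compounds shown here, compound 4 also brings in a ring, so a fall is expected in this assay, though the group entering is not the one in compound 3, and compound 1, whose nitrogen likewise carries a ring-bearing group and a hydrogen, gives 96%. The expected step is therefore moderate: a number 16 percentage points lower from compound 2 to compound 4 (beyond the scatter).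

Compound 4 is estimated at 75%, with a range from 45% to 95%.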

Compound 4, a percentage reported as inhibition, at one concentration (the size of the read-out at that concentration, not a potency): 25%
Compound 4: middle estimate off by 50 percentage points, on the high side; the measured number lies below the stated range.
By their numbers in this assay, from the lowest: compound 4; then compound 3; then compounds 2 and 1 (each within the scatter of the next).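

In this assay, among the compounds shown here, the group on the aromatic carbon next to the ring nitrogen can take the number much further down than the earlier compounds showed: (pyridin-2-yl)amino in place of methyl(propyl)amino gives a number 66 percentage points lower from compound 2 to compound 4 (beyond the scatter). A hydrogen on the attached nitrogen does not by itself keep the number high, since compound 1 and compound 4 both carry one, yet pyridin-2-yl in place of cyclohexylmethyl gives a number 71 percentage points lower from compound 1 to compound 4 (beyond the scatter), so what sits on that nitrogen matters strongly. No measurement is available to explain why this change has so large an effect.

The compounds shown leave open which feature of pyridin-2-yl goes with the fall: the ring nitrogen, the aromatic ring itself, or the ring sitting directly on the amino nitrogen instead of one carbon away, as the ring of cyclohexylmethyl does. A plain phenyl group on that nitrogen would separate the ring nitrogen from the aromatic ring, and a benzyl or pyridin-2-ylmethyl group would test the effect of the one-carbon link.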